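Trading (diethylamino)methyl for diethylamino in compound 2

The source may report more compounds than this note shows. Statements on the series, on what has been measured and on what is new or still open speak of the compounds shown alone.

Compound 1 `CCN(CC)CCCN/C(=N\c1ccnc2cc(Cl)ccc12)c1cccnc1` gives > 1 h
Compound 2 `CCN(CC)CCCCCN/C(C)=N\c1ccnc2cc(Cl)ccc12` gives > 1 h
Compound 3 `C/C(=N/c1ccnc2cc(Cl)ccc12)NC1CCN(Cc2ccccc2)CC1` gives > 1 h

These three results come from an ADME assay (liver, Mus musculus) for metabolic stability, read by LC-MS, using microsomes, tested at 1 uM; on this read-out lower numbers stand for a shorter-lived compound and higher numbers for a longer-lived compound. Compound 2 stands at > 1 h, which is a limit of the assay and not a number. The other two compounds offer no firmer reference point, as the summary of the set shows: the limit of > 1 h in this assay, at which 3 of the 3 values shown sit.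

Compound 4 `CCN(CC)CCCCN/C(C)=N\c1ccnc2cc(Cl)ccc12` has not yet been measured. It differs from compound 2 in one place: diethylamino in place of (diethylamino)methyl on a saturated chain carbon, four bonds along the chain from an amine nitrogen. In words, diethylamino takes the place of (diethylamino)methyl on a saturated chain carbon, four bonds along the chain from an amine nitrogen.

Among the compounds with values here, no two measured compounds differ in a single place, so no measured step sets a size for this change. The expectation in this assay is therefore for no shift beyond the scatter, in either direction. The expected step is a step that the limit leaves unreadable from compound 2 to compound 4. A result reported only as a limit is also likely for compound 4. Compound 4 is estimated at 1.5 h, with an expected range from 0.7 h to 3 h.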

Compound 4, half-life: > 1 h
Compound 4 ended at the assay's limit; the forecaster's own chance of this, stated with the estimate: 75%; the middle value lies beyond the limit too.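

Compound 2 and compound 4 both end at a limit rather than a number, so the step between them cannot be read: the limit of > 1 h in this assay, at which 4 of the 4 values shown sit.

The compounds shown leave open how long each one actually lasts, and whether diethylamino in place of (diethylamino)methyl changes the half-life at all.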